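This account rests on a few compounds, and the source may have more. Where it says the series, first, only, none or still open, it means among the compounds named here.

For the measured compounds named here, in a functional assay on Jurkat cells (Homo sapiens) for inhibition, read by MTT assay, with a stated time of 72 h (a higher number here means a weaker inhibitor of growth, a lower number a stronger inhibitor of growth), compound 2 `COC(=O)c1nc(C2CCCC2)n(-c2ccc(F)cc2)n1` gives 9550 nM, the only number among the two values shown. Compound 1 `CCCCc1nc(C(=O)OC)nn1-c1ccc(F)cc1` reaches only a limit, > 100000 nM, which is the limit of > 100000 nM in this assay, at which 1 of the 2 values shown sits. Going by the values given here, the single measured step, an at least 10-fold lower number from compound 1 to compound 2 (1.01 log units; beyond the scatter), was large. Compound 3 `COC(=O)c1nc(-c2ccoc2)n(-c2ccc(F)cc2)n1` differs from compound 2 by furan-3-yl in place of cyclopentyl on an aromatic carbon. That earlier step bears only loosely on this one, since it exchanged two non-aromatic carbon groups, whereas here an aromatic ring with one hydrogen-bond acceptor enters. The step is therefore expected to stay within the scatter, a 1.3-fold higher number from compound 2 to compound 3 (0.10 log units; within the scatter). Compound 3 is estimated at 12000 nM, between 3000 nM and 50000 nM.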

Compound 3, concentration for 50% growth inhibition: 9320 nM
The estimate for compound 3 lay 1.3-fold (0.11 log units) above the measured number; measured number inside the range.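

In this assay, the aromatic furan-3-yl and the non-aromatic cyclopentyl cannot be told apart on this aromatic carbon, although furan-3-yl adds a hydrogen-bond acceptor: the exchange gives a 1.0-fold lower number from compound 2 to compound 3 (0.01 log units; within the scatter). Furan-3-yl in place of butyl likewise gives an at least 10-fold lower number from compound 1 to compound 3 (1.03 log units; beyond the scatter), so both five-membered rings shown differ from butyl beyond the scatter. Compound 1 stands at a limit and not at a number: the limit of > 100000 nM in this assay, at which 1 of the 3 values shown sits.

From the compounds shown here alone, whether a phenyl ring, an isopropyl group or an amine on this carbon would side with the two five-membered rings or with butyl stays open.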